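The source may report more compounds than this note shows. Statements on the series, on what has been measured and on what is new or still open speak of the compounds shown alone.

Working notes on the series. In a functional assay on A549 cells (Homo sapiens) for inhibition, read by sulforhodamine B assay, with a stated time of 48 h, tested at 50 uM (on this read-out higher numbers stand for more inhibition of growth at the one concentration tested and lower numbers for less inhibition of growth), compound 2 `COc1cc2c(cc1CC=C(C)C)C(=O)C[C@@H](c1ccc(Oc3cccc([N+](=O)[O-])c3)cc1)O2` gives 37%. This lies within the scatter of its nearest comparisons: compound 3 `COc1ccc([C@@H]2C/C(=N/OCc3cn(-c4cccc(CO)c4)nn3)c3cc(CC=C(C)C)c(OC)cc3O2)cc1` at 43% and compound 1 `COc1cc2c(cc1CC=C(C)C)C(=O)C[C@@H](c1ccc(Oc3ccc(F)cc3)cc1)O2` at 27%. The next structure, compound 4 `CCOc1ccc([C@@H]2CC(=O)c3cc(CC=C(C)C)c(OC)cc3O2)cc1`, differs from compound 2 as follows: ethyl in place of 3-nitrophenyl on an oxygen on an aromatic ring. In words, this is ethyl in place of 3-nitrophenyl on an oxygen on an aromatic ring, or 3-nitrophenoxy to ethoxy.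

Going by the values given here, only one measured step bears on this place: a number 10 percentage points higher from compound 1 to compound 2 (within the scatter), which lies within the scatter and exchanges 4-fluorophenyl for 3-nitrophenyl. Among the compounds with values here, that step keeps an aromatic ring on the oxygen, and no measured step removes it, so the evidence for the present change is thin. Within the data shown here, compound 3 differs in more than one place and supplies no step here. From the compounds shown here alone, no step beyond the scatter is therefore expected in this assay, and the direction remains open, with only a slight lean downward. The expected step is a number 5 percentage points lower from compound 2 to compound 4 (within the scatter). For compound 4 the estimated value is 32%, with an expected range of 14% to 52%.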

Compound 4, percent growth inhibition at one concentration: 37%
Compound 4: the middle estimate sits 5 percentage points below what was measured, and the stated range covers the measured number.
By their numbers in this assay, from the lowest: compounds 1, 2, 4 and 3 (each within the scatter of the next, the first and the last beyond it).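

In this assay, the aromatic ring on this oxygen turns out not to be required to hold the read-out: ethyl in place of 3-nitrophenyl gives no change at the digits printed from compound 2 to compound 4 (within the scatter), and ethyl in place of 4-fluorophenyl gives a number 10 percentage points higher from compound 1 to compound 4 (within the scatter). Compound 1 and compound 2 both carry an aromatic ring at this place, so only compound 4 shows that a small chain without a ring stays within the scatter of both. Nothing at hand offers an explanation for this result.

From the compounds shown here alone, whether the position also accepts a longer chain such as hexyl, or a terminal amine or carboxylic acid on an ethyl chain, remains open. Going by these compounds, with a single concentration as the read-out, any difference between these compounds at other concentrations also remains open.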